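Aryl amine halogen swap in the quinoline ether series

The source may report more compounds than this note shows. Statements on the series, on what has been measured and on what is new or still open speak of the compounds shown alone.

Compound 1 `CN1CCN(CCCOc2cccc3nc(Nc4cccc(Cl)c4)ccc23)CC1` carries a 3-chlorophenyl amine on the shared core and in a functional assay on NCI-H322M cells (Homo sapiens) for inhibition, read by sulforhodamine B assay, with a stated time of 48 h (a lower number here means a stronger inhibitor of growth, a higher number a weaker inhibitor of growth), compound 1 gives 2670 nM. For the measured compounds named here, compound 2 `CN1CCN(CCCOc2cccc3nc(Nc4cc(Cl)cc(Cl)c4)ccc23)CC1` carries the 3,5-dichlorophenyl amine; in this assay compound 2 gives 1560 nM, the lowest of the two numbers so far, with compound 1 its only neighbour. Going by the values given here, the one measured step, a 1.7-fold lower number from compound 1 to compound 2 (0.23 log units; within the scatter), separates them. Compound 3 `CN1CCN(CCCOc2cccc3nc(Nc4ccc(Cl)c(F)c4)ccc23)CC1` differs from compound 2 in one place: 4-chloro-3-fluorophenyl in place of 3,5-dichlorophenyl on a nitrogen on an aromatic ring. Among the compounds with values here, the step from compound 1 to compound 2 is the only measured step bearing on a change of halogen pattern on the aryl amine, and it stays within the scatter, so for compound 3 no step beyond the scatter is expected in this assay, with the estimated shift a 1.2-fold higher number from compound 2 to compound 3 (0.09 log units; within the scatter). The value expected for compound 3 is 1900 nM, within 700 nM to 5000 nM.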

Compound 3, concentration for 50% growth inhibition: 1700 nM
Compound 3: the middle estimate sits 1.1-fold (0.05 log units) above what was measured; the measured number falls inside the stated range.
By their numbers in this assay, from the lowest: compounds 2, 3 and 1 (each within the scatter of the next).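

In this assay, 4-chloro-3-fluorophenyl in place of 3,5-dichlorophenyl on the nitrogen gives a 1.1-fold higher number from compound 2 to compound 3 (0.04 log units; within the scatter) and in place of 3-chlorophenyl gives a 1.6-fold lower number from compound 1 to compound 3 (0.20 log units; within the scatter) in the same series. This adds a fluorine-bearing pattern to the two chlorine-only patterns, and none of the three steps among these compounds leaves the scatter, so this assay does not separate the three aryl groups on this nitrogen. No measurement is available that would explain this result.

Still open, on these data alone, is whether a group other than a halogen on this aryl ring, such as methoxy, nitrile or trifluoromethyl, would give a step beyond the scatter. Also open, as far as these compounds go, is what a bare phenyl on this nitrogen, or a longer chain on the ether oxygen, would give.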